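Cyclopropylamino in place of dimethylamino on the core of compound 1

The compounds below may be only part of what the source reports. "The series", "measured", "known", "first", "only" and "open" are said of these compounds alone.

Among the compounds with values here, compound 1 `CCC(C)n1cnc2c(N(C)C)ncnc21` gives 14 mg/kg in a functional assay on the whole organism for antagonist activity, with Rattus norvegicus as the target (on this read-out lower numbers stand for an effect already at smaller amounts and higher numbers for an effect only at larger amounts of compound), the highest of the three numbers known so far: compound 2 `CN(C)c1ncnc2c1ncn2CC1CC1` gives 4.5 mg/kg and compound 3 `CN(C)c1ncnc2c1ncn2C1CCC1` gives 11 mg/kg. All three measured steps concern only the group on the aromatic nitrogen: a 3.1-fold lower number from compound 1 to compound 2 (0.49 log units; beyond the scatter), a 1.3-fold lower number from compound 1 to compound 3 (0.10 log units; within the scatter) and a 2.4-fold higher number from compound 2 to compound 3 (0.39 log units; beyond the scatter). Compound 4 `CCC(C)n1cnc2c(NC3CC3)ncnc21` differs from compound 1 at another place, by cyclopropylamino in place of dimethylamino on an aromatic carbon. Within the data shown here, no measured step touches this position, so nothing among the three compounds speaks for a shift in either direction. The step is therefore expected to stay within the scatter, no change at the digits printed from compound 1 to compound 4 (within the scatter). Compound 4 is estimated at 14 mg/kg in this assay, within a range from 5 mg/kg to 40 mg/kg.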

Compound 4, dose for half-maximal effect: 13.5 mg/kg
Compound 4: middle estimate off by 1.0-fold (0.02 log units), on the high side, within the range that was stated.
By their numbers in this assay, from the lowest: compound 2; then compounds 3, 4 and 1 (each within the scatter of the next).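

The step of a 1.0-fold lower number from compound 1 to compound 4 (0.02 log units; within the scatter) shows, in this assay, that this aromatic carbon accepts cyclopropylamino in place of dimethylamino with no shift beyond the scatter. The change adds a hydrogen-bond donor and a three-membered ring, and with sec-butyl on the aromatic nitrogen neither brings a measurable difference in this read-out. No measurement at hand accounts for this result. As far as these compounds go, whether the exchange behaves the same with cyclopropylmethyl or cyclobutyl on the aromatic nitrogen stays open. So does the outcome with an unsubstituted amine or a morpholine at this carbon.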